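The compounds below may be only part of what the source reports. "The series", "measured", "known", "first", "only" and "open" are said of these compounds alone.

Measured in an ADME assay on the whole organism (plasma) for pharmacokinetics, with Rattus norvegicus as the target, with a stated time of 6 h, at a dose of 10 mg/kg by the oral route; on this read-out higher numbers stand for higher exposure at the dose given and lower numbers for lower exposure:

- compound 1 `CC1(COc2c(N3CCN(S(=O)(=O)Cc4ccc(N)cc4)CC3)cnn(-c3cccc(Cl)c3)c2=O)CC1`: 8100 ng.h/mL
- compound 2 `CC1(COc2c(N3CCN(S(=O)(=O)Cc4cccc(N)c4)CC3)cnn(-c3cccc(Cl)c3)c2=O)CC1`: 5700 ng.h/mL
- compound 3 `CC1(COc2c(N3CCN(S(=O)(=O)Cc4ccc(N)c(C(F)(F)F)c4)CC3)cnn(-c3cccc(Cl)c3)c2=O)CC1`: 640 ng.h/mL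

Among these three, compound 3 stands lowest at 640 ng.h/mL. Moving the amino group changes little, with a 1.4-fold lower number from compound 1 to compound 2 (0.15 log units; within the scatter). Placing trifluoromethyl in place of hydrogen on an aromatic carbon gives a much larger change, with a 13-fold lower number from compound 1 to compound 3 (1.10 log units; beyond the scatter). The other route to the same compound is similar in size, with an 8.9-fold lower number from compound 2 to compound 3 (0.95 log units; beyond the scatter).

The next compound is compound 4 `COc1cc(CS(=O)(=O)N2CCN(c3cnn(-c4cccc(Cl)c4)c(=O)c3OCC3(C)CC3)CC2)ccc1N`. It carries methoxy in place of trifluoromethyl on an aromatic carbon, ortho to an amino group: methoxy in place of trifluoromethyl on an aromatic carbon. Within the data shown here, no measured compound carries methoxy, so the size of this step is uncertain. Compound 1 lacks trifluoromethyl and reads 8100 ng.h/mL, so a rise is expected, though perhaps only part of the way back to that number. The expected step is a 3.9-fold higher number from compound 3 to compound 4 (0.59 log units; beyond the scatter). For compound 4 the estimated value is 2500 ng.h/mL, with an expected range from 700 ng.h/mL to 8000 ng.h/mL.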

Compound 4, area under the concentration-time curve: 13100 ng.h/mL
Beside the measured number, compound 4's estimate is 5.2-fold (0.72 log units) below it; the whole stated range lies below it.
By their numbers in this assay, from the lowest: compound 3; then compounds 2, 1 and 4 (each within the scatter of the next, the first and the last beyond it).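

On the aromatic carbon ortho to an amino group, the choice of group decides the outcome: in this assay, methoxy in place of trifluoromethyl gives a 20-fold higher number from compound 3 to compound 4 (1.31 log units; beyond the scatter), so the low exposure of compound 3 belongs to trifluoromethyl, not to every group placed there. Methoxy in place of hydrogen gives a 1.6-fold higher number from compound 1 to compound 4 (0.21 log units; within the scatter), so compound 1 and compound 4 cannot be told apart, and this position accepts methoxy without a visible loss. The step from the isomer with the amino group moved, a 2.3-fold higher number from compound 2 to compound 4 (0.36 log units; beyond the scatter), is modest but beyond the scatter.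

Nothing shown here explains why trifluoromethyl and methoxy differ so widely. From the compounds shown here alone, it also remains open whether a fluorine atom, a chlorine atom, a methyl group or an ethoxy group at this position would read closer to methoxy or to trifluoromethyl.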